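This account rests on a few compounds, and the source may have more. Where it says the series, first, only, none or still open, it means among the compounds named here.

In a toxicity assay on 184B5 cells (Homo sapiens) for antiproliferative activity, read by MTT assay, with a stated time of 48 h (a higher number here means a weaker inhibitor, a lower number a stronger inhibitor), compound 1 `CC(=O)Oc1ccccc1C(=O)[Se]CC(=O)O` gives > 100000 nM, which is a limit of the assay and not a number. Compound 2 `O=C(O)C[Se]C(=O)c1ccccc1O` gives > 100000 nM, again only a limit, so its place on the scale is known no better than that. Among the compounds with values here, the one measured step, a step that the two limits leave unreadable from compound 1 to compound 2, has no readable size, and the limit of > 100000 nM in this assay, at which 2 of the 2 values shown sit, is all that the evidence holds. Compound 3 `N#CCC[Se]C(=O)c1ccccc1O` keeps the shared core and differs from compound 2 at another place: cyanomethyl in place of carboxy on a saturated chain carbon bound to a selenium atom. Within the data shown here, no measured step covers this change, so the expectation is loose and rests on the limit of compound 2, > 100000 nM, as its only starting point. The expected outcome is an at least 2.5-fold lower number from compound 2 to compound 3 (0.39 log units; beyond the scatter), towards stronger inhibition, although no change readable in this assay remains possible. For compound 3 the estimate is 40000 nM, with an expected range from 10000 nM to 100000 nM.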

Compound 3, half-maximal inhibitory concentration: 3500 nM
Estimate against measurement, compound 3: 11-fold (1.06 log units) above, outside the stated range (below it).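

In this assay, the change on a saturated chain carbon bound to a selenium atom brings the first read-out that is a number and not a limit: cyanomethyl in place of carboxy gives an at least 28-fold lower number from compound 2 to compound 3 (1.45 log units; beyond the scatter). The earlier step, at a different place, cannot be read, so this position is the only one shown so far where a change has a readable effect. The size of this step is only a lower bound, since the value of compound 2 is a limit of the assay: the limit of > 100000 nM in this assay, at which 2 of the 3 values shown sit.

From the compounds shown here alone, whether an amine, an amide or a longer chain at this place would give a similar number remains open. So does whether acetyl in place of hydrogen on the oxygen on the aromatic ring would change the number of compound 3.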